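This account rests on a few compounds, and the source may have more. Where it says the series, first, only, none or still open, it means among the compounds named here.

Compound 1 `Cc1nc(C)c([C@H](OC(C)(C)C)C(=O)O)c(N2CCC(C)(C)CC2)c1-c1ccc(Oc2ccccc2)cc1` carries the shared core with a phenyl group on an oxygen on an aromatic ring, while compound 2 `COc1ccc(CCOc2ccc(-c3c(C)nc(C)c([C@H](OC(C)(C)C)C(=O)O)c3N3CCC(C)(C)CC3)cc2)cc1` and compound 3 `COc1cccc(CCOc2ccc(-c3c(C)nc(C)c([C@H](OC(C)(C)C)C(=O)O)c3N3CCC(C)(C)CC3)cc2)c1` carry a 2-(4-methoxyphenyl)ethyl and a 2-(3-methoxyphenyl)ethyl group at that place. In a toxicity assay on MT2 cells (Homo sapiens) for cytotoxicity, read by XTT assay, with a stated time of 4 days (on this read-out lower numbers stand for higher toxicity in this test and higher numbers for lower toxicity in this test), compound 1 reached only a limit, >= 20000 nM. Compound 2 likewise reached only a limit, >= 33500 nM. Compound 3 also stands at a limit, >= 33500 nM. Its position among the three is set only by the limit of >= 33500 nM in this assay, at which 2 of the 3 values shown sit, alongside (the limit of >= 20000 nM in this assay, at which 1 of the 3 values shown sits). The steps a step that the two limits leave unreadable from compound 1 to compound 2, a step that the two limits leave unreadable from compound 1 to compound 3 and a step that the two limits leave unreadable from compound 2 to compound 3 are therefore all unreadable in size. Compound 4 `Cc1nc(C)c([C@H](OC(C)(C)C)C(=O)O)c(N2CCC(C)(C)CC2)c1-c1ccc(OCCc2ccc(Cl)cc2)cc1` differs from compound 3 by 4-chlorophenyl in place of 3-methoxyphenyl on a saturated chain carbon, two bonds along the chain from an oxygen on an aromatic ring. For the measured compounds named here, no measured step gives a readable size, so no change beyond the scatter is expected, and the value is expected to remain a limit. The expected step of a number no higher from compound 3 to compound 4 (the limit leaves the size open) is thus flat. Compound 4 is estimated at 33500 nM, between 15000 nM and 100000 nM.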

Compound 4, half-maximal cytotoxic concentration: >= 33500 nM
Compound 4 was reported as a limit; the forecaster's own chance of this, stated with the estimate: 85%; the middle value sits exactly at the limit.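

In this assay compound 4 gives only a limit, >= 33500 nM, so the steps to it from compound 1, compound 2 and compound 3 cannot be read in size. The compounds shown leave open at what concentration any of them becomes cytotoxic in this assay, and whether the group at this place matters.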